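One Small Change to Compound 3: What to Expect

The source may report more compounds than this note shows. Statements on the series, on what has been measured and on what is new or still open speak of the compounds shown alone.

Of the compounds shown here, three have so far been measured in a functional assay on the whole organism (liver, strain Wistar) for inhibition, with Rattus norvegicus as the target, with a stated time of 3 h, at a dose of 3 mg/kg by the oral route; a lower number here means less inhibition, a higher number more inhibition at the dose given (going by the name of the read-out). Compound 1 `O=[N+]([O-])c1cc(-c2nc(-c3ccccc3)no2)cc(O)c1O` gives 20.6% in this assay. Compound 2 `Cc1ccc(-c2noc(-c3cc(O)c(O)c([N+](=O)[O-])c3)n2)c(Br)[n+]1[O-]` gives 33.7%. Compound 3 `O=[N+]([O-])c1cc(-c2nc(-c3c[n+]([O-])ccc3C(F)(F)F)no2)cc(O)c1O` gives 23.6%. Among these three numbers compound 3 stands second highest. Its nearest neighbour is compound 1, whose number sits within the usual scatter of it, while compound 2 lies furthest away, with a number higher than that of compound 3 by more than the scatter.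

Compound 4 `O=[N+]([O-])c1cc(-c2nc(-c3ccc[n+]([O-])c3)no2)cc(O)c1O` has not yet been measured. It differs from compound 3 in one place: hydrogen in place of trifluoromethyl on an aromatic carbon. Among the measured compounds shown here, no measured pair shows what this swap, hydrogen in place of trifluoromethyl on an aromatic carbon, does on its own, and the three measured numbers occupy a fairly narrow band. Compound 4 is therefore expected to stay near compound 3. The step of a number 1.6 percentage points lower from compound 3 to compound 4 (within the scatter) is expected to fall within the scatter, in no clear direction. The estimate for compound 4 is 22%, with a range from 10% to 35%.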

Compound 4, a percentage reported as inhibition, in the whole organism at one dose (the size of the read-out at that dose, not a potency): 77%
The estimate for compound 4 lay 55 percentage points below the measured number; measured number outside the range, above it.
By their numbers in this assay, from the lowest: compounds 1 and 3 (each within the scatter of the next); then compound 2; then compound 4.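

Trifluoromethyl on this aromatic carbon, opposite the ring nitrogen, matters far more than the narrow band of earlier numbers suggested: hydrogen in its place gives a number 53.4 percentage points higher from compound 3 to compound 4 (beyond the scatter) in this assay, the first sign that this position strongly affects the read-out. Compound 4 also stands well apart from the compound with the ring of carbon only, with a number 56.4 percentage points higher from compound 1 to compound 4 (beyond the scatter) for the exchange of that ring, so two different single changes that lead to compound 4 each come with a large step. Nothing available explains why the number rises so far.

From the compounds shown here alone, whether only hydrogen gives so high a number on this carbon, or whether a methyl group or a chlorine atom there would do the same, stays open. Also open, going by these compounds, is whether the same swap would have a similar effect in other compounds with the shared core.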